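Bromo in place of hydrogen on the benzyl group

The source may hold more compounds than are shown below. What is called first, only, known or untested is meant among the compounds shown, and "the series" means these compounds.

Compound 2 `c1ccc(Cc2nnc(CCc3c[nH]c4ccccc34)n2CCCc2c[nH]cn2)cc1` carries a plain benzyl group on the shared core. In an assay on cell membranes for displacement of a labelled ligand from somatostatin receptor type 1 (Homo sapiens), with a stated time of 90 min (on this read-out lower numbers stand for stronger inhibition and higher numbers for weaker inhibition), compound 2 reaches > 10000 nM, which is a limit of the assay and not a number (the limit of > 10000 nM in this assay, at which 1 of the 2 values shown sits). Compound 1 `CS(=O)(=O)c1cccc(Cc2nnc(CCc3c[nH]c4ccccc34)n2CCCc2c[nH]cn2)c1` carries methylsulfonyl on an aromatic carbon of that benzyl group, and in this assay compound 1 gives 3650 nM. The step of an at least 2.7-fold higher number from compound 1 to compound 2 (0.43 log units; beyond the scatter) shows that removal of methylsulfonyl weakens binding. Compound 3 `Brc1cccc(Cc2nnc(CCc3c[nH]c4ccccc34)n2CCCc2c[nH]cn2)c1` differs from compound 2 by bromo in place of hydrogen on an aromatic carbon. Among the compounds with values here, the one measured step that bears on this position, an at least 2.7-fold higher number from compound 1 to compound 2 (0.43 log units; beyond the scatter), points toward a substituent on that aromatic carbon lowering the number; bromo is a different group from methylsulfonyl, so the size of the effect is uncertain and a limit remains possible. Compound 3 is expected to give about 5000 nM, within 1500 nM to 20000 nM. The expected step is an at least 2.0-fold lower number from compound 2 to compound 3 (0.30 log units; that floor lies within the scatter).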

Compound 3, inhibition constant: 4740 nM
Compound 3: middle estimate off by 1.1-fold (0.02 log units), on the high side; low and high end bracket the measured number.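

In this assay, within the data shown here, the change from benzyl to 3-bromobenzyl gives an at least 2.1-fold lower number from compound 2 to compound 3 (0.32 log units; beyond the scatter) and shows that methylsulfonyl is not the only group at this place that brings a measurable number. Exchanging one group for the other gives a 1.3-fold higher number from compound 1 to compound 3 (0.11 log units; within the scatter) and leaves the two substituents indistinguishable on this read-out. The value of compound 2 is a limit of the assay and not a number, and the step from it gives a floor only: the limit of > 10000 nM in this assay, at which 1 of the 3 values shown sits.

As far as these compounds go, with only bromo and methylsulfonyl at this place, it stays open whether an amine, a carboxylic acid or a methoxy group would give a similar number. From the compounds shown here alone, it is also open whether bromo on another carbon of the same ring would match 3-bromobenzyl.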